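Swapping methyl for methoxy: an expectation for compound 4

A few compounds are considered here, and "the series" means these few. Any claim that something is new, unique, unknown or untested is made for them only; others in the source may bear on it.

Compound 1 `COc1ccc(-n2cc(NC(=O)c3cccc(NS(=O)(=O)c4ccccc4)c3)cn2)cc1`: 76800 nM
Compound 2 `O=C(Nc1cnn(-c2ccccc2)c1)c1cccc(NS(=O)(=O)c2ccc(Cl)cc2)c1`: 19300 nM
Compound 3 `Cc1ccc(-n2cc(NC(=O)c3cccc(NS(=O)(=O)c4ccc(Cl)cc4)c3)cn2)cc1`: 15600 nM

In a functional assay on A549 cells (Homo sapiens) for inhibition, read by MTT assay, with a stated time of 48 h (a lower number here means a stronger inhibitor, a higher number a weaker inhibitor), compound 3 gives the lowest of the three numbers. Its nearest neighbour is compound 2, and the step of a 1.2-fold lower number from compound 2 to compound 3 (0.09 log units; within the scatter) is within the scatter, so the two cannot be ordered; compound 1 is the furthest, beyond the scatter. Compound 4 `COc1ccc(-n2cc(NC(=O)c3cccc(NS(=O)(=O)c4ccc(Cl)cc4)c3)cn2)cc1` differs from compound 3 in one place: methoxy in place of methyl on an aromatic carbon. For the measured compounds named here, no measured pair isolates this change; compound 1 and compound 2 differ in two places at once, so their values cannot be split. With nothing bearing directly on it, the step is expected to stay near compound 3, a 1.3-fold higher number from compound 3 to compound 4 (0.11 log units; within the scatter), and compound 4 is estimated at 20000 nM with a range of 7000 nM to 55000 nM.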

Compound 4, half-maximal inhibitory concentration: 29700 nM
Compound 4: middle estimate off by 1.5-fold (0.17 log units), on the low side, and the stated range covers the measured number.
By their numbers in this assay, from the lowest: compounds 3, 2 and 4 (each within the scatter of the next); then compound 1.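

In this assay, the two steps at this position, a 1.9-fold higher number from compound 3 to compound 4 (0.28 log units; within the scatter) and a 1.5-fold higher number from compound 2 to compound 4 (0.19 log units; within the scatter), show that hydrogen, methyl and methoxy cannot be told apart here. For the compounds shown here, the change that does read lies elsewhere: gaining a chloro group gives a 2.6-fold lower number from compound 1 to compound 4 (0.41 log units; beyond the scatter), a modest step and the first single change beyond the scatter. Nothing available explains either finding. From the compounds shown here alone, whether an amine or a carboxylic acid at this position would leave the scatter stays open, as does whether a longer chain would. The chloro step also rests on this one pair, with methoxy in place.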